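From Cyclohexyl to Trifluoromethylphenyl: Expected Cell Tolerance

The compounds below may be only part of what the source reports. "The series", "measured", "known", "first", "only" and "open" are said of these compounds alone.

Three compounds sharing one core were tested in an ADME assay on Vero cells (Chlorocebus sabaeus) for cytotoxicity, read by MTT assay, with a stated time of 72 h; a higher number here means that more compound is tolerated, a lower number that less compound is tolerated. Compound 1 `O=c1nc(N2CCN(NC3CCCCC3)CC2)sc2c([N+](=O)[O-])cc(C(F)(F)F)cc12` reports only a limit of the assay, > 64 ug/mL. Compound 3 `CON=C1CCC(N(C)N2CCN(c3nc(=O)c4cc(C(F)(F)F)cc([N+](=O)[O-])c4s3)CC2)CC1` likewise stops at a limit, > 64 ug/mL. Among the compounds with values here, compound 2 `O=c1nc(N2CCN(NCC3CCCCC3)CC2)sc2c([N+](=O)[O-])cc(C(F)(F)F)cc12` is the one member that yields a number in this assay, 29.3 ug/mL. That makes compound 2 the single measured point of the three, since the other two stand at the limit of > 64 ug/mL in this assay, at which 2 of the 3 values shown sit. The step of an at least 2.1-fold lower number from compound 1 to compound 2 (0.33 log units; beyond the scatter) shows cyclohexylmethyl in place of cyclohexyl lowering the tolerated concentration, while an at least 2.1-fold higher number from compound 2 to compound 3 (0.33 log units; beyond the scatter) runs upward again. Compound 4 `O=c1nc(N2CCN(NCc3ccc(C(F)(F)F)cc3)CC2)sc2c([N+](=O)[O-])cc(C(F)(F)F)cc12` differs from compound 2 by 4-(trifluoromethyl)phenyl in place of cyclohexyl on a saturated chain carbon bound to an amine nitrogen. Within the data shown here, no measured step exchanges a saturated ring for an aromatic one, so nothing among the three sets the size or direction of this change; both neighbours of compound 2 sit at the limit, which leaves an upward move at least as plausible as a downward one. Compound 4 is therefore expected to give about 40 ug/mL in this assay, between 15 ug/mL and 64 ug/mL. This expectation means a step of a 1.4-fold higher number from compound 2 to compound 4 (0.14 log units; within the scatter).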

Compound 4, half-maximal cytotoxic concentration: > 64 ug/mL
Compound 4 ended at the assay's limit (the forecaster's own chance of this, stated with the estimate: 35%); middle value at least 1.6-fold (0.20 log units) from the limit.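

In this assay, within the data shown here, 4-(trifluoromethyl)phenyl in place of cyclohexyl on a saturated chain carbon bound to an amine nitrogen gives an at least 2.1-fold higher number from compound 2 to compound 4 (0.33 log units; beyond the scatter), the first step at this position that exchanges a saturated ring for an aromatic one. The earlier at least 2.1-fold lower number from compound 1 to compound 2 (0.33 log units; beyond the scatter) could be read as a cost of the added chain carbon, but compound 4 keeps that carbon and still reaches a limit of the assay rather than a number. Compound 2 remains the only one with a number, and the steps among the other compounds cannot be read: the limit of > 64 ug/mL in this assay, at which 3 of the 4 values shown sit.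

On these data alone, whether the aromatic ring or its trifluoromethyl group carries the change stays open, and a plain benzyl group would separate the two. As far as these compounds go, how a longer chain, such as 2-phenylethyl, would behave at this position also remains open.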